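A few compounds are considered here, and "the series" means these few. Any claim that something is new, unique, unknown or untested is made for them only; others in the source may bear on it.

Measured compounds:
compound 1 `CN(C)CCCNc1nc(-c2ccc(NC(=O)Nc3ccccc3F)cc2)nc2ccsc12`, in a functional assay on HT-29 cells (Homo sapiens) for cytotoxicity, read by MTT assay, with a stated time of 72 h (a lower number here means a stronger inhibitor, a higher number a weaker inhibitor), compound 1 gives 470 nM
compound 2 `CN(C)CCNc1nc(-c2ccc(NC(=O)Nc3ccc(F)cc3)cc2)nc2ccsc12`, in this assay compound 2 gives 350 nM
compound 3 `CN(C)CCNc1nc(-c2ccc(NC(=O)Nc3ccc(Cl)cc3)cc2)nc2c(Cl)c(Cl)sc12`, in this assay compound 3 gives 460 nM

Among these three numbers compound 2 has the lowest, but its gap to compound 3 and its gap to compound 1 both lie within the scatter of the method, so the three compounds cannot be ranked against one another on this evidence. Compound 4 `CN(C)CCNc1nc(-c2ccc(NC(=O)Nc3ccc(Cl)cc3Cl)cc2)nc2ccsc12` has not yet been measured in this assay. It differs from compound 2 in one place: 2,4-dichlorophenyl in place of 4-fluorophenyl on an amide-type nitrogen. Within the data shown here, no pair of the measured compounds differs in only one place, so no single change can be read off directly; what the set shows is that a different ring on the urea nitrogen in compound 1, and a different ring together with a changed core in compound 3, both leave the number within the scatter of compound 2. On that basis the step from compound 2 to compound 4 is expected to be small, a 1.1-fold higher number from compound 2 to compound 4 (0.06 log units; within the scatter), with no direction that can be told from the data. Compound 4 is therefore estimated at 400 nM in this assay, with a range from 150 nM to 1200 nM.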

Compound 4, half-maximal inhibitory concentration: 1320 nM
Compound 4: the middle estimate sits 3.3-fold (0.52 log units) below what was measured, outside the stated range (above it).
By their numbers in this assay, from the lowest: compounds 2, 3 and 1 (each within the scatter of the next); then compound 4.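

In this assay, replacing 4-fluorophenyl with 2,4-dichlorophenyl on the amide-type nitrogen gives a 3.8-fold higher number from compound 2 to compound 4 (0.58 log units; beyond the scatter), a modest step but one beyond the scatter. Among these compounds, this is the first change in the set that can be read on its own, as no earlier pair differed in only one place, and it shows that with the core and the dimethylaminoethyl chain of compound 2 held fixed, the number responds to the aryl group on this urea nitrogen. Nothing shown accounts for the step, so the result stands as an observation without an established cause.

The entering group changes both the kind of halogen and the number of halogens in a single step, and the compounds shown do not separate these two changes, so it stays open whether the higher number goes with the chlorines together or with only one of them. Also open, as far as these compounds go, is how plain phenyl or a methoxyphenyl group would read on this same nitrogen with the core of compound 2.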